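Pyridinyl Position Change in an Indole Thromboxane Antagonist Series

This account rests on a few compounds, and the source may have more. Where it says the series, first, only, none or still open, it means among the compounds named here.

Measured so far:
- compound 1, `Cc1c(Cn2ccnc2)c2cc(CCC(=O)O)ccc2n1CCNS(=O)(=O)c1ccc(F)cc1`: 1.59 nM
- compound 2, `Cc1c(Cc2cccnc2)c2cc(CCC(=O)O)ccc2n1CCNS(=O)(=O)c1ccc(F)cc1`: 0.692 nM

Compound 2 stands at the lowest number of the two measured in a functional assay on aorta for antagonist activity at thromboxane A2 receptor (Rattus norvegicus); on this read-out higher numbers stand for weaker binding and lower numbers for tighter binding; its nearest neighbour is compound 1, and the step of a 2.3-fold lower number from compound 1 to compound 2 (0.36 log units; beyond the scatter) is the only one recorded, with pyridin-3-yl replacing 1H-imidazol-1-yl on a saturated chain carbon bound to an aromatic carbon.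

Compound 3, `Cc1c(Cc2ccncc2)c2cc(CCC(=O)O)ccc2n1CCNS(=O)(=O)c1ccc(F)cc1`, has not yet been measured in this assay. It differs from compound 2 by pyridin-4-yl in place of pyridin-3-yl on a saturated chain carbon bound to an aromatic carbon; the two compounds have the same atoms joined differently, pyridin-4-yl entering where pyridin-3-yl leaves, on a saturated chain carbon bound to an aromatic carbon.

Within the data shown here, no measured step covers a move of the ring nitrogen within a pyridinyl group. Among the measured compounds shown here, the single recorded step concerns a different ring, so it gives no direct guidance here, only a sense that the heteroaryl group at this site does move the number modestly. With one hydrogen-bond acceptor kept in both cases, the expected step for compound 3 is a 1.4-fold higher number from compound 2 to compound 3 (0.16 log units; within the scatter), which is within the usual scatter.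

Compound 3 is therefore estimated at 1 nM in this assay, with a range from 0.3 nM to 3.5 nM.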

Compound 3, dissociation constant: 0.0741 nM
For compound 3 the middle estimate is 13-fold (1.13 log units) above the measured one; the whole stated range lies above it.
By their numbers in this assay, from the lowest: compound 3; then compound 2; then compound 1.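

Working notes: in this assay, the site on a saturated chain carbon bound to an aromatic carbon responds to the place of the ring nitrogen alone. With the heavy atoms and the hydrogen-bond donor and acceptor counts unchanged, pyridin-4-yl in place of pyridin-3-yl gives a 9.3-fold lower number from compound 2 to compound 3 (0.97 log units; beyond the scatter), so the two pyridinyl groups cannot be treated as interchangeable here. Against the first heteroaryl group, pyridin-4-yl in place of 1H-imidazol-1-yl gives a 21-fold lower number from compound 1 to compound 3 (1.33 log units; beyond the scatter), which puts compound 3 lowest of the three, with every step among them beyond the scatter, and no measurement at hand bears on why the place of the nitrogen matters so much.

Still open, as far as these compounds go, is how pyridin-2-yl, a plain phenyl ring or a methyl-substituted pyridin-4-yl would read at this same place, and whether a longer chain between the ring and the core would keep the number of compound 3. Also open, from the compounds shown here alone, is whether the preference for pyridin-4-yl over pyridin-3-yl would survive a change elsewhere in the molecule, such as a tetrazole in place of the carboxylic acid.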